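Working notes: thiophene change from compound 1 to compound 4

A few compounds are considered here, and "the series" means these few. Any claim that something is new, unique, unknown or untested is made for them only; others in the source may bear on it.

In a functional assay on cells (Cancer cell lines, Homo sapiens) for inhibition (on this read-out higher numbers stand for weaker inhibition of growth and lower numbers for stronger inhibition of growth), compound 1 `Cc1cc(-c2nc3sc(C)cn3c2/C=N/NC(=N)N)c(C)s1` gives 8320 nM. Its nearest neighbour on the numbers is compound 2 `Cc1cn2c(/C=N/Nc3ccccn3)c(-c3ccc(Cl)c([N+](=O)[O-])c3)nc2s1` at 7760 nM, within the scatter. The furthest is compound 3 `Cc1cc(-c2nc3sccn3c2/C=N/NC(=N)N)c(C)s1` at 15500 nM, also within the scatter.

Compound 4 `Cc1cn2c(/C=N/NC(=N)N)c(-c3cccs3)nc2s1` keeps the core of compound 1 and changes only the thiophene: thiophen-2-yl in place of 2,5-dimethylthiophen-3-yl on an aromatic carbon.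

For the measured compounds named here, no measured step alters that thiophene, so the evidence is indirect. Going by the values given here, the one step at hand is a 1.9-fold higher number from compound 1 to compound 3 (0.27 log units; within the scatter), and it concerns a different methyl, one that compound 4 retains. It shows only that losing a single methyl from compound 1 left the number within the scatter. Compound 2 carries different groups on the core and adds nothing to this comparison. A small rise in the number is expected, with no clear move beyond the scatter. The expected change is a 1.4-fold higher number from compound 1 to compound 4 (0.16 log units; within the scatter). The estimate for compound 4 is 12000 nM, with an expected range of 4500 nM to 32000 nM.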

Compound 4, concentration for 50% growth inhibition: 4270 nM
Compound 4: the middle estimate sits 2.8-fold (0.45 log units) above what was measured; measured number below the stated range.
By their numbers in this assay, from the lowest: compounds 4, 2, 1 and 3 (each within the scatter of the next, the first and the last beyond it).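

For the compounds shown here, this is the first measured step at this position of the shared core: in this assay, thiophen-2-yl in place of 2,5-dimethylthiophen-3-yl gives a 1.9-fold lower number from compound 1 to compound 4 (0.29 log units; within the scatter). The position therefore tolerates the smaller thiophene without a move beyond the scatter, even though the two methyl groups go and the point of attachment on the thiophene changes in the same step. Nothing at hand gives a reason for this reading, so it stands as an observation only.

Going by these compounds alone, the single step cannot separate the loss of the methyl groups from the change in attachment, since both occur together. It also leaves open how far this tolerance extends, for example to an unsubstituted phenyl ring, a carboxylic acid or an amine at this position.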